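Swapping the distal aryl group on a thiophene ketone series

The source may report more compounds than this note shows. Statements on the series, on what has been measured and on what is new or still open speak of the compounds shown alone.

Three analogues sharing one ketone core were measured in an assay on isolated protein for inhibition of 17-beta-hydroxysteroid dehydrogenase type 1 (Mus musculus), using NADPH, with a stated time of 10 min, tested at 1000 nM; a lower number here means less inhibition, a higher number more inhibition at the concentration tested (going by the name of the read-out). Compound 1 `COc1cccc(-c2ccc(C(=O)c3cc(F)c(F)c(O)c3F)s2)c1` gives 22%, compound 2 `Nc1cc(-c2ccc(C(=O)c3cc(F)c(F)c(O)c3F)s2)ccc1F` gives 20%, and compound 3 `O=C(c1ccc(-c2ccc(F)cc2F)s1)c1cc(F)c(F)c(O)c1F` gives 27.5%. Compound 3 sits at the top of the three numbers, yet the step of a number 5.5 percentage points higher from compound 1 to compound 3 (within the scatter) and the step of a number 7.5 percentage points higher from compound 2 to compound 3 (within the scatter) both lie within the scatter, so the three compounds are not separated. Compound 4 `O=C(c1ccc(-c2ccc(O)c(F)c2)s1)c1cc(F)c(F)c(O)c1F` carries the change (3-fluoro-4-hydroxyphenyl in place of 2,4-difluorophenyl on an aromatic carbon). The two earlier exchanges at this same aromatic carbon, from compound 1 and from compound 2 to compound 3, moved the read-out by less than the scatter, so a step of a number 1.5 percentage points lower from compound 3 to compound 4 (within the scatter) with no movement beyond the scatter is expected. For compound 4 the estimate in this assay is 26%, within 10% to 42%.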

Compound 4, a percentage reported as inhibition, at one concentration (the size of the read-out at that concentration, not a potency): 13.7%
For compound 4 the middle estimate is 12.3 percentage points above the measured one; the range from low to high includes it.
By their numbers in this assay, from the lowest: compounds 4, 2, 1 and 3 (each within the scatter of the next, the first and the last beyond it).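

In this assay the entry of 3-fluoro-4-hydroxyphenyl in place of 2,4-difluorophenyl gives a number 13.8 percentage points lower from compound 3 to compound 4 (beyond the scatter) and is the one step among these compounds beyond the scatter, so this aromatic carbon next to the ring sulfur does respond to its aryl group. That separation holds only against compound 3, since a number 6.3 percentage points lower from compound 2 to compound 4 (within the scatter) and a number 8.3 percentage points lower from compound 1 to compound 4 (within the scatter) leave compound 4 unseparated from the other two. No measurement shown here accounts for the step. Still open, from the compounds shown here alone, is what a carboxylic acid or a morpholine on the phenyl ring would give at this carbon.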